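This account rests on a few compounds, and the source may have more. Where it says the series, first, only, none or still open, it means among the compounds named here.

Measured compounds:
- compound 1, `CC(C)(C)OC(=O)N1CCN(C(=S)SCc2cn(-c3ccccc3F)nn2)CC1`: 119000 nM
- compound 2, `O=C(OCc1ccccc1)N1CCN(C(=S)SCc2cn(Cc3ccccc3F)nn2)CC1`: 5060 nM
- compound 3, `S=C(SCc1cn(Cc2ccccc2Cl)nn1)N1CCNCC1`: 45200 nM

In a functional assay on MGC-803 cells (Homo sapiens) for inhibition, read by MTT assay, with a stated time of 72 h (a lower number here means a stronger inhibitor, a higher number a weaker inhibitor), compound 1 gives 119000 nM, the highest of the three numbers and therefore the weakest inhibitor of this small set. Compound 3 stands nearest to it, and its value of 45200 nM is beyond the scatter. Compound 2 lies furthest away, with 5060 nM, also well beyond the scatter. Both compounds 2 and 3 carry a benzyl-type group on the ring nitrogen where compound 1 carries 2-fluorophenyl.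

Compound 4, `CC(C)(C)OC(=O)N1CCN(C(=S)SCc2cn(Cc3ccc(Cl)cc3)nn2)CC1`, has not yet been measured. It keeps the shared core and the tert-butyl carbamate of compound 1, and differs only in this way: 4-chlorobenzyl in place of 2-fluorophenyl on an aromatic nitrogen. Among the measured compounds shown here, no measured pair shows this exact change. Still, the two measured compounds that bear a benzyl-type group on that nitrogen give lower numbers than compound 1, so a step toward stronger inhibition beyond the scatter is expected. The estimated step is a 7.9-fold lower number from compound 1 to compound 4 (0.90 log units; beyond the scatter) in this assay. For compound 4 the expected value is 15000 nM, with a range from 4000 nM to 60000 nM.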

Compound 4, half-maximal inhibitory concentration: 9790 nM
For compound 4 the middle estimate is 1.5-fold (0.19 log units) above the measured one; measured number inside the range.
By their numbers in this assay, from the lowest: compounds 2 and 4 (each within the scatter of the next); then compound 3; then compound 1.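

With the tert-butyl carbamate held constant, this assay now isolates the group on the aromatic nitrogen: 4-chlorobenzyl in place of 2-fluorophenyl gives a 12-fold lower number from compound 1 to compound 4 (1.08 log units; beyond the scatter) with no other change to the molecule. Among the compounds shown here, this shows that the group at this position can by itself move the number by a large step, which the earlier compounds could not show, as each differed from the others in more than one place. Nothing measured here explains the size or direction of this step.

The compounds shown leave open which part of the change matters: the extra carbon of the benzyl group, chlorine for fluorine, or the place of the halogen on the ring. Also open, on these data alone, is how a longer chain such as 2-phenylethyl would behave on this nitrogen.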